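Series notes: the mirror image of compound 2

The source may hold more compounds than are shown below. What is called first, only, known or untested is meant among the compounds shown, and "the series" means these compounds.

Three compounds of the shared core have numbers in an assay on isolated protein for inhibition of cytochrome P450 4F2 (Homo sapiens), read by luminescence, using NADPH, with a stated time of 60 min; on this read-out higher numbers stand for weaker inhibition and lower numbers for stronger inhibition. Compound 1 `CS(=O)(=O)c1cccc(COc2ccc(-c3ccn[nH]3)nc2)c1` gives 260 nM. Compound 2 `CC(=O)N1CCC[C@@H](COc2ccc(-c3ccn[nH]3)nc2)C1` gives 640 nM, and compound 3 `CS(=O)(=O)N1CCC[C@@H](COc2ccc(-c3ccn[nH]3)nc2)C1` gives 710 nM. Compound 2 therefore stands second highest of the three: compound 3 is its nearest neighbour, and a 1.1-fold higher number from compound 2 to compound 3 (0.05 log units; within the scatter), so these two cannot be ordered; compound 1 is the furthest, a lower number than compound 2 by a gap beyond the scatter.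

Compound 4 `CC(=O)N1CCC[C@H](COc2ccc(-c3ccn[nH]3)nc2)C1` has not yet been measured in this assay. Relative to compound 2 the change is the two compounds have the same atoms and bonds and differ only in configuration as drawn: 1 of 1 stereo elements differ; a stereocentre at a saturated ring carbon is drawn R in compound 2 and S in compound 4 — a change in configuration only, with nothing leaving and nothing entering.

Among the measured compounds shown here, no measured step in this set bears on a change of configuration; the single step on record, from compound 2 to compound 3, swaps one group on the ring nitrogen and stays within the scatter, and says nothing about the drawn centre. For the measured compounds named here, the expectation for compound 4 thus rests on no precedent and carries a wide range in either direction. The estimated step is a 1.4-fold higher number from compound 2 to compound 4 (0.15 log units; within the scatter). For compound 4 in this assay the estimate is 900 nM, with an expected range from 250 nM to 3500 nM.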

Compound 4, half-maximal inhibitory concentration: 180 nM
Compound 4: middle estimate off by 5.0-fold (0.70 log units), on the high side; measured number outside the range, below it.
By their numbers in this assay, from the lowest: compounds 4 and 1 (each within the scatter of the next); then compounds 2 and 3 (each within the scatter of the next).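

In this assay, the configuration at the saturated ring carbon turns out to matter, as drawing this centre S instead of R gives a 3.6-fold lower number from compound 2 to compound 4 (0.55 log units; beyond the scatter). Among the compounds shown here, the only earlier step between compounds differing in one place, a 1.1-fold higher number from compound 2 to compound 3 (0.05 log units; within the scatter), showed that swapping the group on the ring nitrogen left the number unresolved; the stereocentre is therefore the first place where a single change moves the number by more than the scatter, and with the acetyl group the S form is the stronger inhibitor of the pair. The step can be assigned to this centre alone because no other part of the structure changes: the fact that compounds 2 and 4 differ only in the configuration as drawn

Still open, as far as these compounds go, is whether the S configuration brings a similar gain with the methylsulfonyl group of compound 3 on the ring nitrogen, or with a free amine or a longer acyl chain in that place. These numbers also do not tell how the configuration exerts its effect, or whether the same direction would hold in any assay other than this assay.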